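Demethylation of a pyrazolyl urea series: growth inhibition compared

The compounds below may be only part of what the source reports. "The series", "measured", "known", "first", "only" and "open" are said of these compounds alone.

Measured compounds:
compound 1 `COc1cc(-c2nn(-c3cccc(NC(=O)Nc4ccc(Cl)c(Cl)c4)c3)cc2-c2ccncc2)ccc1Cl`: 2620 nM
compound 2 `O=C(Nc1cccc(-n2cc(-c3ccncc3)c(-c3ccc(Cl)c(O)c3)n2)c1)Nc1ccc(Cl)c(Cl)c1`: 3570 nM
compound 3 `COc1cc(-c2nn(-c3cccc(NC(=O)Nc4ccc(Cl)c(C(F)(F)F)c4)c3)cc2-c2ccncc2)ccc1Cl`: 4610 nM

In a functional assay on LOX IMVI cells (Homo sapiens) for inhibition, read by sulforhodamine B assay, with a stated time of 48 h (on this read-out higher numbers stand for weaker inhibition of growth and lower numbers for stronger inhibition of growth), compound 1 gives 2620 nM. Compound 2 differs from compound 1 by hydrogen in place of methyl on an oxygen on an aromatic ring and in this assay compound 2 gives 3570 nM, a step of a 1.4-fold higher number from compound 1 to compound 2 (0.13 log units; within the scatter). Compound 3 differs from compound 1 by trifluoromethyl in place of chloro on an aromatic carbon, and compound 3 gives 4610 nM, a step of a 1.8-fold higher number from compound 1 to compound 3 (0.25 log units; within the scatter).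

Compound 4 `O=C(Nc1cccc(-n2cc(-c3ccncc3)c(-c3ccc(Cl)c(O)c3)n2)c1)Nc1ccc(Cl)c(C(F)(F)F)c1` has not yet been measured. It differs from compound 3 by hydrogen in place of methyl on an oxygen on an aromatic ring, which is the same change, at the same place, as that from compound 1 to compound 2. Since the earlier step was a 1.4-fold higher number from compound 1 to compound 2 (0.13 log units; within the scatter), a step of similar size, a 1.4-fold higher number from compound 3 to compound 4 (0.15 log units; within the scatter), is expected from compound 3 to compound 4, resting on that single precedent. Compound 4 is therefore estimated at 6500 nM, with a range from 3000 nM to 14000 nM.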

Compound 4, concentration for total growth inhibition: 1150 nM
Compound 4: the middle estimate sits 5.7-fold (0.75 log units) above what was measured; measured number outside the range, below it.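

In this assay, methoxy to hydroxy gives a 4.0-fold lower number from compound 3 to compound 4 (0.60 log units; beyond the scatter), so this change does not carry over unaltered from the core of compound 1 to the core of compound 3: the same change on two cores in this assay, a 1.4-fold higher number (0.13 log units; within the scatter) from compound 1 to compound 2 and a 4.0-fold lower number (0.60 log units; beyond the scatter) from compound 3 to compound 4, 5.5-fold (0.74 log units) apart, beyond the scatter of two such steps

Read the other way, trifluoromethyl in place of chloro gives a 3.1-fold lower number from compound 2 to compound 4 (0.49 log units; beyond the scatter), and this step also differs from its earlier counterpart: the same change on two cores in this assay, a 1.8-fold higher number (0.25 log units; within the scatter) from compound 1 to compound 3 and a 3.1-fold lower number (0.49 log units; beyond the scatter) from compound 2 to compound 4, 5.5-fold (0.74 log units) apart, beyond the scatter of two such steps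

Both comparisons rest on the same four compounds, so together they show a single case in which the outcome of each change depends on the other group present, but they do not show why, or whether this holds beyond these compounds.

The compounds shown leave open whether the stronger growth inhibition of compound 4 requires the hydroxy group or would also appear with an amine in its place. They also leave open how a nitrile in place of trifluoromethyl would behave alongside the hydroxy group.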